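Chlorophenyl for Methylphenyl in a Weakly Active Pair

The source may report more compounds than this note shows. Statements on the series, on what has been measured and on what is new or still open speak of the compounds shown alone.

Compound 1, `CCCSc1nc(N/N=C(\C)c2ccccc2O)c2nnn(Cc3ccc(Cl)cc3)c2n1`: in a functional assay on ECa-109 cells (Homo sapiens) for antiproliferative activity, read by MTT assay, with a stated time of 72 h (a lower number here means a stronger inhibitor, a higher number a weaker inhibitor), compound 1 gives 11200 nM.
Compound 2, `CCCSc1nc(N/N=C/c2ccc(C)cc2)c2nnn(Cc3ccccc3)c2n1`: in this assay compound 2 gives > 64000 nM, a limit of the assay rather than a number.

Going by these compounds, compound 2 therefore stands at the weak end of the two values shown, and its exact potency is unknown because the assay reports only (the limit of > 64000 nM in this assay, at which 1 of the 2 values shown sits). Going by the values given here, compound 1 sits at a measured number, but the two compounds differ in more than one place, so their values alone show only that compound 1 is the measured one of the pair.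

Compound 3, `CCCSc1nc(N/N=C/c2ccccc2Cl)c2nnn(Cc3ccccc3)c2n1`, differs from compound 2 by 2-chlorophenyl in place of 4-methylphenyl on a carbon with a double bond to nitrogen. Among the compounds with values here, no step between measured compounds bears on this change, so its effect is open. Compound 3 is expected to remain weak in this assay, with a step from compound 2 estimated as an at least 1.6-fold lower number from compound 2 to compound 3 (0.20 log units; that floor lies within the scatter). Compound 3 is estimated at 40000 nM, within a range of 10000 nM to 160000 nM.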

Compound 3, half-maximal inhibitory concentration: 6180 nM
For compound 3 the middle estimate is 6.5-fold (0.81 log units) above the measured one, outside the stated range (below it).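

In this assay, 2-chlorophenyl in place of 4-methylphenyl on a carbon with a double bond to nitrogen gives an at least 10-fold lower number from compound 2 to compound 3 (1.01 log units; beyond the scatter). This shows that the group at this place matters for antiproliferative activity on the shared core, even though the two groups match in heavy atoms and in their counts of hydrogen-bond donors and acceptors. The step can be stated only as a floor because compound 2 sits at a limit of the assay rather than at a number: the limit of > 64000 nM in this assay, at which 1 of the 3 values shown sits.

The change alters both the substituent and its position on the ring, so the compounds shown do not separate the effect of chlorine from that of its place. Going by these compounds, how 2-methylphenyl or 2-aminophenyl would fare at this place remains open.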